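The compounds below may be only part of what the source reports. "The series", "measured", "known", "first", "only" and "open" are said of these compounds alone.

Measured so far:
compound 1 `COc1cc(-c2nn(-c3cccc(NC(=O)Nc4cc(C(F)(F)F)cc(C(F)(F)F)c4)c3)cc2-c2ccncc2)ccc1Cl` — 590 nM
compound 2 `COc1cc(-c2nn(-c3cccc(NC(=O)Nc4ccc(Cl)c(Cl)c4)c3)cc2-c2ccncc2)ccc1Cl` — 820 nM
compound 3 `O=C(Nc1cccc(-n2cc(-c3ccncc3)c(-c3ccc(Cl)c(O)c3)n2)c1)Nc1ccc(Cl)c(Cl)c1` — 1510 nM

All three numbers come from a functional assay on U-251 cells (Homo sapiens) for inhibition, read by sulforhodamine B assay, with a stated time of 48 h; on this read-out higher numbers stand for weaker inhibition of growth and lower numbers for stronger inhibition of growth. Compound 1 and compound 2 differ in more than one place; the difference between the two cores is not broken down here. Compound 2 and compound 3 differ by hydrogen in place of methyl on an oxygen on an aromatic ring, and that change gives a 1.8-fold higher number from compound 2 to compound 3 (0.27 log units; within the scatter). Compound 4 `O=C(Nc1cccc(-n2cc(-c3ccncc3)c(-c3ccc(Cl)c(O)c3)n2)c1)Nc1cc(C(F)(F)F)cc(C(F)(F)F)c1` has not yet been measured; it differs from compound 1 by hydrogen in place of methyl on an oxygen on an aromatic ring, the same change at the same place as before.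

Going by the values given here, the step from compound 1 to compound 4 in this assay is expected to be about a 1.8-fold higher number from compound 1 to compound 4 (0.25 log units; within the scatter), resting on the only precedent, the step of a 1.8-fold higher number from compound 2 to compound 3 (0.27 log units; within the scatter) made by the same change. Compound 4 is therefore estimated at 1050 nM, with a likely range from 500 nM to 2400 nM.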

Compound 4, concentration for 50% growth inhibition: 463 nM
Estimate against measurement, compound 4: 2.3-fold (0.36 log units) above; the whole stated range lies above it.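

In this assay, the change from methoxy to hydroxy gives a 1.3-fold lower number from compound 1 to compound 4 (0.11 log units; within the scatter). Set beside the earlier step, the two results do not separate: the same change on two cores in this assay, a 1.8-fold higher number (0.27 log units; within the scatter) from compound 2 to compound 3 and a 1.3-fold lower number (0.11 log units; within the scatter) from compound 1 to compound 4, 2.3-fold (0.37 log units) apart, within the scatter of two such steps. On these two cores, then, the change leaves the number within the scatter, but two pairs show neither that the step depends on the core nor that it is the same on every core in the series.

Still open, from the compounds shown here alone, is how other groups on that oxygen would read on either core, for example an ethyl or a longer chain. Also open, going by these compounds, is whether an amine or a carboxylic acid in place of the hydroxy would give a step beyond the scatter.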